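Widening the ether ring on compound 3's aromatic oxygen

The compounds below may be only part of what the source reports. "The series", "measured", "known", "first", "only" and "open" are said of these compounds alone.

Compound 3 `O=C(O)C[C@@H](NC(=O)[C@@H]1CCN1S(=O)(=O)c1cc(Cl)cc(Cl)c1)c1ccc(OC2CC2)cc1` gives the lowest number of the set in an assay on RPMI-8866 cells for inhibition of integrin alpha-4/beta-1 (Homo sapiens) (on this read-out lower numbers stand for stronger inhibition and higher numbers for weaker inhibition), at 0.31 nM. Its nearest neighbour, compound 1 `O=C(O)C[C@@H](NC(=O)[C@@H]1CCN1S(=O)(=O)c1cc(Cl)cc(Cl)c1)c1ccc(F)cc1`, gives 3.2 nM in this assay, and the step of a 10-fold lower number from compound 1 to compound 3 (1.01 log units; beyond the scatter) is large. Compound 2 `COc1ccc([C@@H](CC(=O)O)NC(=O)[C@@H]2CCN2S(=O)(=O)c2cc(Cl)cc(Cl)c2)cc1` gives 0.39 nM; 0.49 nM (2 entries) in this assay, which places it close to compound 3; the repeated readings the several entries of compound 2 in this assay, 0.39 nM; 0.49 nM (2 entries) show how steady such numbers are. Compound 4 `O=C(O)C[C@@H](NC(=O)[C@@H]1CCN1S(=O)(=O)c1cc(Cl)cc(Cl)c1)c1ccc(OC2CCCC2)cc1` carries the change (cyclopentyl in place of cyclopropyl on an oxygen on an aromatic ring). For the measured compounds named here, no measured step swaps one ring for another on that oxygen, so the only guide is that the methoxy of compound 2 and the cyclopropyloxy of compound 3 sit within the scatter of each other. The expected step of a 1.3-fold higher number from compound 3 to compound 4 (0.11 log units; within the scatter) is therefore small, with compound 4 estimated at 0.4 nM, between 0.15 nM and 1.2 nM.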

Compound 4, half-maximal inhibitory concentration: 0.5 nM
Estimate against measurement, compound 4: 1.3-fold (0.10 log units) below; measured number inside the range.
By their numbers in this assay, from the lowest: compounds 3 and 4 (each within the scatter of the next); then compound 1.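

The aromatic oxygen accepts a bigger carbon ring than cyclopropyl: the change to cyclopentyl gives a 1.6-fold higher number from compound 3 to compound 4 (0.21 log units; within the scatter), so the two ethers cannot be told apart here. The advantage over fluoro also holds with the larger ring, at a 6.4-fold lower number from compound 1 to compound 4 (0.81 log units; beyond the scatter). Repeat readings show how closely such numbers can agree: the several entries of compound 2 in this assay, 0.39 nM; 0.49 nM (2 entries)

Still open, going by these compounds, is whether a cyclohexyloxy group, or a longer chain ending in an amine, would keep the number this low on the same oxygen.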